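The source may report more compounds than this note shows. Statements on the series, on what has been measured and on what is new or still open speak of the compounds shown alone.

Notes on the thiosemicarbazone series.

Compound 3 `CC1=CC[C@H](C(C)(C)NC(=S)N/N=C/c2ccc(Cl)cc2)CC1` stands lowest of the two numbers shown: in a functional assay on K562 cells (Homo sapiens) for inhibition, read by sulforhodamine B assay, with a stated time of 48 h (a lower number here means a stronger inhibitor of growth, a higher number a weaker inhibitor of growth), compound 3 gives 16900 nM. Compound 2 `CC1=CC[C@H](C(C)(C)NC(=S)N/N=C/c2ccccc2Cl)CC1` gives 66200 nM in this assay, and the step of a 3.9-fold lower number from compound 2 to compound 3 (0.59 log units; beyond the scatter) lies beyond the scatter. Compound 1 `CC1=CC[C@H](C(C)(C)NC(=S)N/N=C/c2ccc(F)cc2)CC1` gives only a limit in this assay, > 100000 nM. That limit, (the limit of > 100000 nM in this assay, at which 1 of the 3 values shown sits), caps what the steps of an at least 1.5-fold lower number from compound 1 to compound 2 (0.17 log units; that floor lies within the scatter) and an at least 5.9-fold lower number from compound 1 to compound 3 (0.77 log units; beyond the scatter) can say.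

Compound 4 `CC1=CC[C@H](C(C)(C)NC(=S)N/N=C/c2ccc[nH]2)CC1` differs from compound 3 by 1H-pyrrol-2-yl in place of 4-chlorophenyl on a carbon with a double bond to nitrogen. Among the measured compounds shown here, none of the measured steps covers a swap of the whole aryl group for a five-membered ring; they cover only a change of halogen and of its position, so they bear on this step only loosely. The change removes the chloro group that accompanied the lowest number, so a higher number is expected, with wide uncertainty. For compound 4 the expected step is a 2.7-fold higher number from compound 3 to compound 4 (0.43 log units; beyond the scatter). In this assay compound 4 is estimated at 45000 nM, within a range of 10000 nM to 150000 nM.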

Compound 4, concentration for total growth inhibition: > 100000 nM
Compound 4: a limit, no number; the forecaster's own chance of this, stated with the estimate: 30%; middle value at least 2.2-fold (0.34 log units) from the limit.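

Compound 4 gives a limit, not a number, in this assay, with > 100000 nM as its reading, and it joins compound 1 at that limit: the limit of > 100000 nM in this assay, at which 2 of the 4 values shown sit.

On the carbon with a double bond to nitrogen, 1H-pyrrol-2-yl in place of 4-chlorophenyl gives an at least 5.9-fold higher number from compound 3 to compound 4 (0.77 log units; beyond the scatter), so this five-membered aromatic ring does not keep the lowest number seen in the series. Against 2-chlorophenyl the change gives an at least 1.5-fold higher number from compound 2 to compound 4 (0.17 log units; that floor lies within the scatter), a floor that does not separate the two compounds, and the step to compound 1 cannot be read, as both values are limits.

Still open, from the compounds shown here alone, is whether the higher number goes with the five-membered ring itself or only with the loss of chloro. An unsubstituted phenyl, a 1-methylpyrrol-2-yl or a 4-aminophenyl on this carbon would bear on that question.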